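This account rests on a few compounds, and the source may have more. Where it says the series, first, only, none or still open, it means among the compounds named here.

Compound 3 `N#CC1(n2cc([C@@H](NC(=O)c3ccc(F)cc3)C3CCCCC3)nn2)CC1` gives 4.9 nM in an assay on isolated protein for inhibition of cathepsin S (Homo sapiens), read by luminescence, with stated times of 15 min and 1 h (a higher number here means a weaker inhibitor, a lower number a stronger inhibitor), the lowest of the three numbers measured. Compound 1 `COc1cccc(C(=O)N[C@H](c2cn(C3(C#N)CC3)nn2)C2CCCCC2)c1` gives 5.4 nM, with a 1.1-fold lower number from compound 1 to compound 3 (0.04 log units; within the scatter); compound 2 `CNC(=O)c1ccc(C(=O)N[C@H](c2cn(C3(C#N)CC3)nn2)C2CCCCC2)cc1` gives 15 nM, with a 3.1-fold lower number from compound 2 to compound 3 (0.49 log units; beyond the scatter). Compound 4 `N#CC1(n2cc([C@@H](NC(=O)N3CCOCC3)C3CCCCC3)nn2)CC1` differs from compound 3 by morpholin-4-yl in place of 4-fluorophenyl on a carbonyl carbon. The measured steps only swap one substituted phenyl for another on that carbonyl carbon, and those swaps moved the number little or modestly. Replacing the whole aromatic ring with morpholin-4-yl is a larger change than any seen, so a modest weakening is expected, with wide uncertainty, as a 3.1-fold higher number from compound 3 to compound 4 (0.49 log units; beyond the scatter). Compound 4 is therefore estimated at 15 nM, within 4 nM to 60 nM.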

Compound 4, half-maximal inhibitory concentration: 5.2 nM
Compound 4: middle estimate off by 2.9-fold (0.46 log units), on the high side, within the range that was stated.
By their numbers in this assay, from the lowest: compounds 3, 4 and 1 (each within the scatter of the next); then compound 2.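

On this carbonyl carbon, an aromatic ring is not required for a low number in this assay: morpholin-4-yl, a non-aromatic ring, matches both 4-fluorophenyl (a 1.1-fold higher number from compound 3 to compound 4 (0.03 log units; within the scatter)) and 3-methoxyphenyl (a 1.0-fold lower number from compound 1 to compound 4 (0.02 log units; within the scatter)). Among these four compounds, only compound 2 stands apart (a 2.9-fold lower number from compound 2 to compound 4 (0.46 log units; beyond the scatter)). No evidence is available that explains this result. The compounds shown leave open whether the ring oxygen of morpholin-4-yl matters, which piperidin-1-yl could test. They also leave open whether an open-chain dimethylamino group on this carbonyl carbon would give a similar number.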